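The compounds below may be only part of what the source reports. "The series", "measured", "known", "first", "only" and "open" are said of these compounds alone.

In a functional assay on A549 cells (Homo sapiens) for antiproliferative activity, read by MTT assay, with a stated time of 12 h (on this read-out lower numbers stand for stronger inhibition and higher numbers for weaker inhibition), compound 1, with structure `COc1cc(OC)c2c(=O)cc(/C=C/c3ccncc3)oc2c1`, reaches only the assay limit of > 40000 nM. Compound 2, `COc1cc(OC)c2c(=O)cc(/C=C/c3ccc(Cl)cc3)oc2c1`, differs from compound 1 by a 4-chlorophenyl in place of pyridin-4-yl on a double-bonded chain carbon bound to a double-bonded chain carbon. In this assay compound 2 likewise stops at the limit of > 40000 nM. The step that the two limits leave unreadable from compound 1 to compound 2 cannot be read because of the limit of > 40000 nM in this assay, at which 2 of the 2 values shown sit. Within the data shown here, compound 2 thus stands at the limit together with the one other value shown, with no ranked position among the numbers. Compound 3, `COc1cc(OC)c2c(=O)cc(/C=C/c3ccc(F)cc3)oc2c1`, is not yet measured; it carries fluoro in place of chloro on an aromatic carbon. Among the measured compounds shown here, only that unreadable step bears on this change, and it gives neither direction nor size to carry forward. Compound 3 is therefore expected to sit at or beyond the same limit, with an estimated step that the limit leaves unreadable from compound 2 to compound 3 no larger than the scatter. The estimate for compound 3 in this assay is 60000 nM, within 20000 nM to 200000 nM.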

Compound 3, half-maximal inhibitory concentration: 18600 nM
For compound 3 the middle estimate is 3.2-fold (0.51 log units) above the measured one; measured number outside the range, below it.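

With fluoro in place of chloro on an aromatic carbon para to a large group, the series gives its first readable step in this assay: an at least 2.1-fold lower number from compound 2 to compound 3 (0.33 log units; beyond the scatter). So the number at this position does respond to which halogen is present, a response the earlier pair could not show. Measured against pyridin-4-yl, 4-fluorophenyl also gives a readable step, an at least 2.1-fold lower number from compound 1 to compound 3 (0.33 log units; beyond the scatter), whereas 4-chlorophenyl left that comparison unreadable. Both steps give only a lower bound on their size because compound 1 and compound 2 stop at the limit: the limit of > 40000 nM in this assay, at which 2 of the 3 values shown sit.

On these data alone, the true size of these steps stays open. So does the question of whether a plain hydrogen, a methoxy group, an amine or a trifluoromethyl group at this position would lower the number further or raise it again.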